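The compounds below may be only part of what the source reports. "The series", "measured", "known", "first", "only" and "open" are said of these compounds alone.

Measured so far in an assay on CHO cells for displacement of a labelled ligand from adenosine receptor A3 (Homo sapiens), read by scintillation counting, with a stated time of 120 min, tested at 1 uM; a higher number here means more inhibition at the concentration tested (going by the name of the read-out), a lower number less inhibition:
compound 1 `N#Cc1c(N)nc(SCC(N)=O)c(C#N)c1-c1ccc(OCC2CC2)cc1` — 8%
compound 2 `COC(=O)c1cccc(CSc2nc(N)c(C#N)c(-c3ccc(OCC4CC4)cc3)c2C#N)c1` — 4%

Going by the values given here, both measured numbers are small, and compound 1 is not set apart from compound 2 in this assay, since the only step, a number 4 percentage points lower from compound 1 to compound 2 (within the scatter), lies within the scatter. That step changes the group on a saturated chain carbon bound to a sulfur, putting 3-(methoxycarbonyl)phenyl in place of carbamoyl, and the read-out does not move beyond noise.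

Compound 3 `N#Cc1c(N)nc(SCC2=NCCN2)c(C#N)c1-c1ccc(OCC2CC2)cc1` has not been measured. It differs from compound 1 by a group of 5 heavy atoms (3 carbon, 2 nitrogen; one five-membered non-aromatic ring with 2 hetero atoms) in place of a group of 3 heavy atoms (1 carbon, 1 nitrogen, 1 oxygen; no ring), on a saturated chain carbon bound to a sulfur. The step from compound 1 to compound 2 is the only measured one that bears on this position; it was within the scatter and involved a different entering group, so it gives no ground for expecting a step in either direction here. Expected for compound 3 in this assay: a step of a number 2 percentage points higher from compound 1 to compound 3 (within the scatter), that is, none beyond the scatter. The estimate for compound 3 in this assay is 10%, with a range from -5% to 25%.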

Compound 3, a percentage reported as inhibition, at one concentration (the size of the read-out at that concentration, not a potency): 6%
Estimate against measurement, compound 3: 4 percentage points above, within the range that was stated.
By their numbers in this assay, from the lowest: compounds 2, 3 and 1 (each within the scatter of the next).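

In this assay, the group with a five-membered non-aromatic ring with 2 hetero atoms, on a saturated chain carbon bound to a sulfur, is not set apart from carbamoyl, with a number 2 percentage points lower from compound 1 to compound 3 (within the scatter), or from 3-(methoxycarbonyl)phenyl, with a number 2 percentage points higher from compound 2 to compound 3 (within the scatter). This position now carries three entering groups that differ in size and ring content: one without a ring, one with a six-membered aromatic ring of carbon only, and one with a non-aromatic ring holding 2 hetero atoms. All three give small numbers within the scatter of each other, so for these compounds the read-out does not separate the groups at this position. No measurement at hand accounts for this lack of separation.

Still open, on these data alone, is whether any group at this position can lift the read-out beyond the scatter, for example a primary amine, a carboxylic acid or a longer alkyl chain on the same carbon. Also open, as far as these compounds go, is whether a change elsewhere on the shared core would move the number in this assay at all.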